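Fluoro for Methyl on a Pair at the Limit

This account rests on a few compounds, and the source may have more. Where it says the series, first, only, none or still open, it means among the compounds named here.

Measured compounds:
Compound 1, `Cc1ccc(-n2cc(CNC(=O)c3cccc4c3cnn4C(C)C)nn2)c(C)c1`: > 40000 nM
Compound 2, `Cc1ccccc1-n1cc(CNC(=O)c2cccc3c2cnn3C(C)C)nn1`: > 40000 nM

In a functional assay on MGC-803 cells (Homo sapiens) for inhibition, read by MTT assay, with a stated time of 72 h (on this read-out lower numbers stand for stronger inhibition and higher numbers for weaker inhibition), compound 1 gives > 40000 nM, which is a limit of the assay rather than a number. Compound 2, which carries hydrogen in place of methyl on an aromatic carbon, gives > 40000 nM, again only a limit. The step that the two limits leave unreadable from compound 1 to compound 2 can therefore not be read in size. So compound 2 stands only at a limit in this assay, and the limit of > 40000 nM in this assay, at which 2 of the 2 values shown sit, shows that both measured values sit at that same limit.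

Compound 3, `CC(C)n1ncc2c(C(=O)NCc3cn(-c4ccccc4F)nn3)cccc21`, differs from compound 2 by fluoro in place of methyl on an aromatic carbon. Within the data shown here, no measured step covers this exchange; the single measured step concerns a different change and is itself unreadable, so it gives no direction. With both neighbours at the limit, no step beyond the scatter is expected in this assay, and the expected step that the limit leaves unreadable from compound 2 to compound 3 is small. Compound 3 is therefore estimated at 50000 nM, within a range of 15000 nM to 200000 nM, most likely reported again only as a limit.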

Compound 3, half-maximal inhibitory concentration: > 40000 nM
Compound 3: only a limit was reported; the forecaster's own chance of this, stated with the estimate: 80%; the middle value does not contradict the limit.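

In this assay, no step can be read among compound 1, compound 2 and compound 3, because all three stand at a limit rather than at a number: the limit of > 40000 nM in this assay, at which 3 of the 3 values shown sit.

The compounds shown leave open what actual value each compound has, and whether any change on the six-membered aromatic ring would give a number rather than a limit.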